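The compounds below may be only part of what the source reports. "The series", "measured", "known", "first", "only" and "open" are said of these compounds alone.

Compound 3 `CS(=O)(=O)Nc1ccc(F)c2c1CCCC2c1c[nH]cn1` sits among three compounds that share one core and differ only in the group on one aromatic carbon. In an assay on isolated protein for binding affinity to Alpha-1A adrenergic receptor (Rattus norvegicus), read by radioligand binding (on this read-out lower numbers stand for stronger inhibition and higher numbers for weaker inhibition), compound 3 gives 309 nM. Compound 2 `Cc1ccc(NS(C)(=O)=O)c2c1C(c1c[nH]cn1)CCC2` carries a methyl at that place and gives 389 nM; the step of a 1.3-fold lower number from compound 2 to compound 3 (0.10 log units; within the scatter) tells nothing that repeated measurement could not also produce. Compound 1 `CS(=O)(=O)Nc1ccc(O)c2c1CCCC2c1c[nH]cn1` carries a hydroxy there and gives 708 nM; the step of a 2.3-fold lower number from compound 1 to compound 3 (0.36 log units; beyond the scatter) is a modest but real gain, and a 1.8-fold lower number from compound 1 to compound 2 (0.26 log units; within the scatter) stays inside the scatter.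

Compound 4 `CS(=O)(=O)Nc1ccc(Cl)c2c1CCCC2c1c[nH]cn1` is the next variation: chloro in place of fluoro on an aromatic carbon. Among the measured compounds shown here, both measured steps at this place, a 2.3-fold lower number from compound 1 to compound 3 (0.36 log units; beyond the scatter) and a 1.3-fold lower number from compound 2 to compound 3 (0.10 log units; within the scatter), are small, and neither involves a chloro, so no measured step speaks directly to this swap. The expectation in this assay is therefore a step of no more than the usual scatter, in either direction. The estimate for compound 4 is 260 nM, with a range from 100 nM to 700 nM. That estimate means a 1.2-fold lower number from compound 3 to compound 4 (0.07 log units; within the scatter).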

Compound 4, inhibition constant: 447 nM
Beside the measured number, compound 4's estimate is 1.7-fold (0.24 log units) below it; the range from low to high includes it.
By their numbers in this assay, from the lowest: compounds 3, 2, 4 and 1 (each within the scatter of the next, the first and the last beyond it).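

Swapping fluoro for chloro at this place, para to a methanesulfonamido group, gives no readable change in this assay: a 1.4-fold higher number from compound 3 to compound 4 (0.16 log units; within the scatter) and a 1.1-fold higher number from compound 2 to compound 4 (0.06 log units; within the scatter) and a 1.6-fold lower number from compound 1 to compound 4 (0.20 log units; within the scatter) all stay within the scatter. Among the earlier compounds, fluoro stood beyond the scatter from hydroxy (a 2.3-fold lower number from compound 1 to compound 3 (0.36 log units; beyond the scatter)), whereas chloro does not, so that single real gain is not shared by both halogens, even though the two cannot be told apart from each other. No measurement shown here offers a reason for these steps.

From the compounds shown here alone, whether an amine, a carboxylic acid or a longer chain at this place would move the number well beyond the scatter stays open. Going by these compounds, the role of the rest of the shared core also stays open, since these four compounds differ only at this one place.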